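Compound 4: hydrogen in place of hydroxy

The compounds below may be only part of what the source reports. "The series", "measured", "known", "first", "only" and "open" are said of these compounds alone.

Measured in a functional assay (Mus musculus) for inhibition, with a stated time of 5 days; a lower number here means a stronger inhibitor, a higher number a weaker inhibitor:
compound 1 `O=C(O)/C=C/c1cn(-c2ccc(O)cc2)nc1-c1ccc(O)cc1` gives > 100000 nM (a limit)
compound 2 `CCOC(=O)/C=C/c1cn(-c2ccc(O)cc2)nc1-c1ccc(O)cc1` gives 25000 nM
compound 3 `O=Cc1cn(-c2ccc(O)cc2)nc1-c1ccc(O)cc1` gives 44000 nM

Among the compounds with values here, compound 2 cannot be separated from its one measured neighbour. That gap is a 1.8-fold higher number from compound 2 to compound 3 (0.25 log units; within the scatter), and the gap to the limit is an at least 4.0-fold lower number from compound 1 to compound 2 (0.60 log units; beyond the scatter). The limit itself is the limit of > 100000 nM in this assay, at which 1 of the 3 values shown sits.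

Compound 4 `CCOC(=O)/C=C/c1cn(-c2ccc(O)cc2)nc1-c1ccccc1` carries hydrogen in place of hydroxy on an aromatic carbon. Within the data shown here, no measured step touches this hydroxy, since the steps above all alter another group and give only a sense of size. No step beyond the scatter is firmly expected in this assay, in either direction. Compound 2, at 25000 nM, therefore anchors the estimate. The expected change is a 1.2-fold higher number from compound 2 to compound 4 (0.08 log units; within the scatter) overall. For compound 4 the estimate is 30000 nM, with an expected range of 8000 nM to 100000 nM.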

Compound 4, half-maximal inhibitory concentration: 29000 nM
Compound 4: middle estimate off by 1.0-fold (0.01 log units), on the high side; the measured number falls inside the stated range.
By their numbers in this assay, from the lowest: compounds 2, 4 and 3 (each within the scatter of the next). At a limit, above all of these: compound 1.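

In this assay, the change from 4-hydroxyphenyl to phenyl gives a 1.2-fold higher number from compound 2 to compound 4 (0.06 log units; within the scatter). Within the data shown here, this is the first step to touch this hydroxy, and it shows that the number of compound 2 does not depend on the hydroxy at this position, at least while the other hydroxy stays in place. The data on hand offer no explanation for this result.

Going by these compounds, whether a methoxy, an amine or a fluorine at this position would leave the number equally unchanged stays open. So does the outcome of replacing the remaining hydroxy of compound 4 with hydrogen.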